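A few compounds are considered here, and "the series" means these few. Any claim that something is new, unique, unknown or untested is made for them only; others in the source may bear on it.

In a functional assay on BJAB cells (Homo sapiens) for antiproliferative activity, with a stated time of 4 days (a higher number here means that more compound is needed for the effect, a lower number that less compound is needed), compound 3 `Cc1cc(C#N)cc(-c2c(C)nn(-c3nc(-c4ccc(Cl)c(Cl)c4)c(SC(C)C)s3)c2C(=O)O)c1` gives 4800 nM. This stands level with compound 1 `Cc1c(-c2cc(Cl)cc(Cl)c2)c(C(=O)O)nn1-c1nc(-c2cc(Cl)ccc2F)c(SC(C)C)s1`, which in this assay gives 4800 nM; the two figures show no change beyond the scatter. Compound 2 `Cc1c(-c2cc(Cl)cc(Cl)c2)c(C(=O)O)nn1-c1nc(-c2cnn(C)c2)c(SC(C)C)s1` in this assay is reported only as "not active" (no number reported), with no number attached. For the measured compounds named here, no pair of measured compounds differs in a single place, so no measured step is available to lean on.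

Compound 4 `COc1cc(Cl)cc(-c2c(C)nn(-c3nc(-c4ccc(Cl)c(Cl)c4)c(SC(C)C)s3)c2C(=O)O)c1` differs from compound 3 in one place: 3-chloro-5-methoxyphenyl in place of 3-cyano-5-methylphenyl on an aromatic carbon. The group that leaves and the group that enters are of the same size, with one hydrogen-bond acceptor each and no net charge, and the ring they sit on is unchanged.

Going by the values given here, with no measured step between neighbouring compounds, compound 4 is expected to show no step beyond the scatter, and the estimated change no change at the digits printed from compound 3 to compound 4 (within the scatter) is taken as essentially flat. Compound 4 is therefore expected to give about 4800 nM in this assay, with a range from 1500 nM to 15000 nM.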

Compound 4, half-maximal effective concentration: 760 nM
Compound 4: middle estimate off by 6.3-fold (0.80 log units), on the high side, outside the stated range (below it).
By their numbers in this assay, from the lowest: compound 4; then compounds 1 and 3 (each within the scatter of the next).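

The replacement of 3-cyano-5-methylphenyl by 3-chloro-5-methoxyphenyl gives a 6.3-fold lower number from compound 3 to compound 4 (0.80 log units; beyond the scatter) in this assay, the first step beyond the scatter among these compounds. It shows that the aryl group on this aromatic carbon, next to the ring atom that bears a carboxy group, can shift the number even when the group that leaves and the group that enters match in heavy atoms, hydrogen-bond donors and hydrogen-bond acceptors. No measurement shown here accounts for the step.

Both substituents on the phenyl ring differ at once, so the compounds leave open whether the chlorine, the methoxy group, the loss of the nitrile or the loss of the methyl group carries the step. They also leave open how a phenyl ring bearing an amine or a hydroxyl group would read at this position.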